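A few compounds are considered here, and "the series" means these few. Any claim that something is new, unique, unknown or untested is made for them only; others in the source may bear on it.

Of the compounds shown here, three have numbers so far. Compound 1 `O=C(O)Cn1c(SCCOc2cccc3ccccc23)nc2ccccc21` in an assay on HEK293 cells for displacement of a labelled ligand from prostaglandin D2 receptor 2 (Homo sapiens) (on this read-out lower numbers stand for stronger inhibition and higher numbers for weaker inhibition), gives 2000 nM. Compound 2 `CCOC(=O)CCCCCSc1nc2ccccc2n1CC(=O)O` in this assay gives 1010 nM. Compound 3 `O=C(O)Cn1c(SCc2cccc(Cl)c2)nc2ccccc21` in this assay gives 186 nM, the lowest of the three, with both gaps beyond the scatter: compound 2 stands nearer to it and compound 1 furthest from it. No pair among these three differs in a single place, so no measured single step is available to carry over.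

Compound 4 `O=C(O)Cn1c(SCc2cccc(Br)c2)nc2ccccc21` is not yet measured. It differs from compound 3 by bromo in place of chloro on an aromatic carbon. Nothing among the three measured compounds shows what a change of this kind does; the only point of reference is compound 3 itself, whose number in this assay is 186 nM. On that basis no step beyond the scatter is expected in this assay in either direction, and the number for compound 4 is expected to lie near that of compound 3. The step that this estimate means is a 1.1-fold lower number from compound 3 to compound 4 (0.04 log units; within the scatter). Compound 4 is therefore estimated at 170 nM, with a range from 70 nM to 420 nM.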

Compound 4, half-maximal inhibitory concentration: 370 nM
Beside the measured number, compound 4's estimate is 2.2-fold (0.34 log units) below it; the measured number falls inside the stated range.
By their numbers in this assay, from the lowest: compounds 3 and 4 (each within the scatter of the next); then compounds 2 and 1 (each within the scatter of the next).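

In this assay the series now has a pair that differs in a single place, and the change from 3-chlorophenyl to 3-bromophenyl reads a 2.0-fold higher number from compound 3 to compound 4 (0.30 log units; within the scatter) in this pair. This position therefore takes either chloro or bromo without a step beyond the scatter, so this read-out does not separate the two halogens here, although this rests on one pair and says nothing about the same change on any other compound of the series. The compounds shown offer nothing that accounts for this result, and the step stands as an observation only.

Open, going by these compounds, is what this position does with a group other than these two halogens, such as fluoro, methyl, methoxy, trifluoromethyl, nitrile or an amine, and whether any of these gives a step beyond the scatter from compound 3. Also open, on these data alone, are the effects of moving the halogen elsewhere on the ring, of a longer chain between the sulfur and the ring, and of an ethyl ester or an amide in place of the carboxylic acid, each taken as a single change.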